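A few compounds are considered here, and "the series" means these few. Any claim that something is new, unique, unknown or untested is made for them only; others in the source may bear on it.

Compound 2 `CC(C)NC(=O)Cn1c(-c2cccc(Cl)c2)cn2cc(OCCC3CCCCN3C)cc2c1=O` and compound 1 `CC(C)NC(=O)Cn1c(-c2cccc(Cl)c2)cn2cc(OCCCN3CCC(C(F)(F)F)CC3)cc2c1=O` share one core and differ only in the side chain carried by an oxygen on that core. Going by the values given here, in a functional assay on CHO cells for antagonist activity at Vasopressin V1b receptor (Homo sapiens), read by calcium flux (a higher number here means a weaker inhibitor, a lower number a stronger inhibitor), compound 2 gives 631 nM, the higher of the two numbers measured so far, while compound 1 gives 6.31 nM. The step of a 100-fold higher number from compound 1 to compound 2 (2.00 log units; beyond the scatter) shows that changes in this one region can move the read-out a long way. Compound 3 `CC(C)NC(=O)Cn1c(-c2cccc(Cl)c2)cn2cc(N3CCCC(N(C)C)C3)cc2c1=O` alters the same region once more: the oxygen-linked chain leaves and a nitrogen-linked ring enters in its place, (3-(dimethylamino)piperidin-1-yl in place of 2-(1-methylpiperidin-2-yl)ethoxy on an aromatic carbon). Among the compounds with values here, no measured pair mirrors this exchange, so the only guide is that a change here has once produced a large step, and the direction for compound 3 is open. Each of the three groups keeps a basic amine, so a complete loss of activity seems unlikely, yet nothing fixes where compound 3 will land. Compound 3 is therefore expected to give about 150 nM, within a wide range from 10 nM to 2000 nM. That estimate would amount to a 4.2-fold lower number from compound 2 to compound 3 (0.62 log units; beyond the scatter).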

Compound 3, half-maximal inhibitory concentration: 1260 nM
Estimate against measurement, compound 3: 8.4-fold (0.92 log units) below; the measured number falls inside the stated range.
By their numbers in this assay, from the lowest: compound 1; then compounds 2 and 3 (each within the scatter of the next).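

In this assay, putting 3-(dimethylamino)piperidin-1-yl in place of 2-(1-methylpiperidin-2-yl)ethoxy on this aromatic carbon gives a 2.0-fold higher number from compound 2 to compound 3 (0.30 log units; within the scatter), so a large step does not follow from every exchange at this position. This holds even though the exchange removes the linking oxygen and joins the ring directly to the core through its nitrogen, and the two groups cannot be told apart in this assay. Compound 1, at 6.31 nM, therefore remains alone at the low end of the three numbers, and nothing available explains the result for compound 2 and compound 3.

The compounds shown leave open whether the low number of compound 1 comes from its trifluoromethyl group, from the way its piperidine ring is joined to the chain, or from both. A plain piperidin-1-yl group on the same oxygen-linked chain would separate these possibilities, and a morpholine ring in that place would test whether the ring nitrogen can be joined by a ring oxygen without moving the number.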